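The source may hold more compounds than are shown below. What is called first, only, known or untested is meant among the compounds shown, and "the series" means these compounds.

Compound 2 `COc1cc2c(Nc3nc4ccc(C(=O)Nc5c(C)cccc5Cl)cc4s3)ncnc2cc1OCCCN1CCCC1` belongs to a small set built on a shared core, in which only the ring at the end of the side chain is changed. In a functional assay on K562 cells (Homo sapiens) for cytotoxicity, read by WST assay, with a stated time of 72 h (on this read-out higher numbers stand for weaker inhibition and lower numbers for stronger inhibition), compound 2 gives 13300 nM, the highest of the two numbers recorded so far; its nearest neighbour is compound 1 `COc1cc2c(Nc3nc4ccc(C(=O)Nc5c(C)cccc5Cl)cc4s3)ncnc2cc1OCCCN1CCCCC1C`, which in this assay gives 6800 nM, and the step of a 2.0-fold higher number from compound 1 to compound 2 (0.29 log units; within the scatter) lies within the scatter. Compound 3 `COc1cc2c(Nc3nc4ccc(C(=O)Nc5c(C)cccc5Cl)cc4s3)ncnc2cc1OCCCN1CCC(C)CC1` is not yet measured; it differs from compound 2 by 4-methylpiperidin-1-yl in place of pyrrolidin-1-yl on a saturated chain carbon, three bonds along the chain from an oxygen on an aromatic ring. Among the measured compounds shown here, the one measured step that bears on this change runs the other way, from a methylpiperidine ring to the pyrrolidine ring, and was small. A step of similar size back toward a lower number is therefore expected, a 1.9-fold lower number from compound 2 to compound 3 (0.28 log units; within the scatter), though it may not exceed the scatter. Compound 3 is estimated at 7000 nM, with a range from 3000 nM to 16000 nM.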

Compound 3, half-maximal inhibitory concentration: 8300 nM
For compound 3 the middle estimate is 1.2-fold (0.07 log units) below the measured one; measured number inside the range.
By their numbers in this assay, from the lowest: compounds 1, 3 and 2 (each within the scatter of the next).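

In this assay, replacing pyrrolidin-1-yl with 4-methylpiperidin-1-yl gives a 1.6-fold lower number from compound 2 to compound 3 (0.20 log units; within the scatter), while replacing 2-methylpiperidin-1-yl with 4-methylpiperidin-1-yl gives a 1.2-fold higher number from compound 1 to compound 3 (0.09 log units; within the scatter). This position has now carried a five-membered ring and two six-membered rings with the methyl group in different places, and no step among these three compounds exceeds the usual scatter, so ring size and methyl placement show no clear effect within this small set. No supporting measurement is available to explain these numbers.

The compounds shown leave open whether a plain piperidine ring, a morpholine ring or a piperazine ring at the end of the chain would give a number beyond the scatter. The same question remains for an open-chain dimethylamino group or a carboxylic acid at this position.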